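From Dichlorophenyl to Dimethoxyphenyl on a Weak Inhibitor

This account rests on a few compounds, and the source may have more. Where it says the series, first, only, none or still open, it means among the compounds named here.

Compound 1 `O=C(Cn1c(=O)c(/C=C\c2ccncc2)nc2ccccc21)Nc1ccc(Cl)cc1` and compound 2 `O=C(Cn1c(=O)c(/C=C\c2ccncc2)nc2ccccc21)Nc1ccc(Cl)c(Cl)c1` share one core and differ only by chloro in place of hydrogen on an aromatic carbon. In a functional assay on MCF7 cells (Homo sapiens) for inhibition, read by MTT assay, with a stated time of 24 h (a lower number here means a stronger inhibitor, a higher number a weaker inhibitor), compound 1 gives only a limit, > 100000 nM. In this assay, among the compounds with values here, compound 2 gives 47600 nM, the only number among the two values shown. The other value, that of compound 1, is a limit (the limit of > 100000 nM in this assay, at which 1 of the 2 values shown sits). Within the data shown here, the single measured step, an at least 2.1-fold lower number from compound 1 to compound 2 (0.32 log units; beyond the scatter), runs downward.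

Compound 3 `COc1ccc(NC(=O)Cn2c(=O)c(/C=C\c3ccncc3)nc3ccccc32)cc1OC` carries the change (3,4-dimethoxyphenyl in place of 3,4-dichlorophenyl on an amide-type nitrogen). Among the measured compounds shown here, no measured step follows this change directly; the one step known concerns hydrogen to chloro and cannot be read onto methoxy groups replacing chlorines. Both chlorines leave in compound 3, and the only measured direction, an at least 2.1-fold lower number from compound 1 to compound 2 (0.32 log units; beyond the scatter), was a lower number when chloro entered, so the expectation is a number moving back upward, toward weaker inhibition. Compound 3 is therefore expected to give about 85000 nM, between 30000 nM and 250000 nM, an expected step of a 1.8-fold higher number from compound 2 to compound 3 (0.25 log units; within the scatter), with a fair chance that only a limit is reported.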

Compound 3, half-maximal inhibitory concentration: > 100000 nM
Compound 3: only a limit was reported; the forecaster's own chance of this, stated with the estimate: 45%; middle value at least 1.1-fold (0.07 log units) from the limit.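

In this assay, 3,4-dimethoxyphenyl in place of 3,4-dichlorophenyl on the amide-type nitrogen gives an at least 2.1-fold higher number from compound 2 to compound 3 (0.32 log units; beyond the scatter), so the two methoxy groups do not keep what the two chlorines gave at this position. Within the data shown here, the earlier pair showed only chloro entering in place of hydrogen, whereas this change replaces both chlorines at once, and compound 2 remains the only one of the three compounds to give a number rather than a limit: the limit of > 100000 nM in this assay, at which 2 of the 3 values shown sit. From the compounds shown here alone, the values of compound 1 and compound 3 are both limits, so the step between them cannot be read, and any order between those two compounds stays unknown.

What the compounds shown leave open is whether the higher number of compound 3 follows from the chlorines leaving or from the methoxy groups entering, since both happen in the same step. Going by these compounds, it also remains open whether a fluoro group, a nitrile or an amine on this ring, in place of the chlorines, would give a number at all in this assay, or one that differs from that of compound 2.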